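This account rests on a few compounds, and the source may have more. Where it says the series, first, only, none or still open, it means among the compounds named here.

Among the compounds with values here, in a functional assay on NCI-H460 cells (Homo sapiens) for cytotoxicity, read by MTT assay, with a stated time of 48 h (on this read-out lower numbers stand for stronger inhibition and higher numbers for weaker inhibition), compound 1 `COc1cc(/C=C/C(=O)/C=C/c2nc3cc(C)ccc3n2C)ccc1O` gives 7700 nM, the lower of the two numbers so far, and compound 2 `COc1cc(/C=C/C(=O)/C=C/c2nc3c(C)c(C)ccc3n2C)ccc1O` gives 31900 nM. Compound 3 `COc1cc(/C=C/C(=O)/C=C/c2nc3cc([N+](=O)[O-])ccc3n2C)ccc1O` keeps the core of compound 1 but has nitro in place of methyl on an aromatic carbon. Within the data shown here, the only measured step, a 4.1-fold higher number from compound 1 to compound 2 (0.62 log units; beyond the scatter), comes from a different change, methyl in place of hydrogen on an aromatic carbon, so it bears only loosely on this one and gives no direction. Only a small upward step is therefore expected, estimated as a 1.4-fold higher number from compound 1 to compound 3 (0.15 log units; within the scatter). For compound 3 the expected value is 11000 nM, with an estimated range of 3500 nM to 35000 nM.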

Compound 3, half-maximal inhibitory concentration: 6700 nM
Beside the measured number, compound 3's estimate is 1.6-fold (0.22 log units) above it, within the range that was stated.
By their numbers in this assay, from the lowest: compounds 3 and 1 (each within the scatter of the next); then compound 2.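

Swapping methyl for nitro on this aromatic carbon leaves the reading in this assay unchanged within the scatter (a 1.1-fold lower number from compound 1 to compound 3 (0.06 log units; within the scatter)). This position therefore takes a group of three heavy atoms with two hydrogen-bond acceptors in place of a single carbon with no measurable gain or loss, unlike the added methyl of compound 2 (a 4.1-fold higher number from compound 1 to compound 2 (0.62 log units; beyond the scatter)), a different change. Nothing available explains why methyl and nitro read alike here. From the compounds shown here alone, whether this tolerance extends to other groups stays open: an amine or a carboxylic acid on this carbon could read differently.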